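The source may report more compounds than this note shows. Statements on the series, on what has been measured and on what is new or still open speak of the compounds shown alone.

Measured compounds in this series:

Compound 1 `CCOc1ccc(N/N=C2\CCC(C)n3c2ncc(C(=O)O)c3=O)cc1`. In a functional assay on the whole organism for inhibition, with Rattus norvegicus as the target (on this read-out lower numbers stand for an effect already at smaller amounts and higher numbers for an effect only at larger amounts of compound), compound 1 gives > 100 umol/kg, a limit.
Compound 2 `CC1CC/C(=N\Nc2ccc(C(F)(F)F)cc2)c2ncc(C(=O)O)c(=O)n21`. In this assay compound 2 gives > 1000 umol/kg, a limit.
Compound 3 `CC(=O)c1ccc(N/N=C2\CCC(C)n3c2ncc(C(=O)O)c3=O)cc1`. In this assay compound 3 gives > 100 umol/kg, a limit.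

Compound 3 therefore stands only at a limit in this assay, and the two further values shown are limits as well. The step to compound 4 `CC1CC/C(=N\Nc2ccc(-c3ccccc3)cc2)c2ncc(C(=O)O)c(=O)n21` is phenyl in place of acetyl on an aromatic carbon. The measured steps that bear on it are a step that the two limits leave unreadable from compound 1 to compound 3 and a step that the two limits leave unreadable from compound 2 to compound 3, which both end at compound 3, and a step that the two limits leave unreadable from compound 1 to compound 2; none of the three is readable in size or direction, because the limit of > 100 umol/kg in this assay, at which 2 of the 3 values shown sit, and the limit of > 1000 umol/kg in this assay, at which 1 of the 3 values shown sits, together cover every value in the set. No readable step is available, so no direction beyond the scatter is expected for a step that the limit leaves unreadable from compound 3 to compound 4, and compound 4 is expected to sit near the same region as the limits shown. The estimate for compound 4 is 300 umol/kg, with a range from 100 umol/kg to 1000 umol/kg, and a limit rather than a number is the most likely outcome.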

Compound 4, dose for 50% inhibition: > 100 umol/kg
Compound 4: a limit, no number; the forecaster's own chance of this, stated with the estimate: 70%; the middle value is on the limit's open side.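

In this assay compound 4 gives > 100 umol/kg, a limit. Among the compounds shown here, no step from compound 1, compound 2 or compound 3 to compound 4 can be read. The compounds shown leave open whether ethoxy, trifluoromethyl, acetyl or phenyl on the aromatic carbon makes any difference in this assay.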